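The compounds below may be only part of what the source reports. "The series", "measured", "known", "first", "only" and "open" are said of these compounds alone.

Compound 1 `CN(Cc1ccc(C(=O)O)cc1)c1ccc(OCc2c(-c3c(Cl)cccc3Cl)noc2C2CC2)nc1C(F)(F)F` is measured in an assay on isolated protein for agonist activity at Bile acid receptor (Homo sapiens), read by FRET (on this read-out lower numbers stand for smaller maximal responses and higher numbers for larger maximal responses), and gives 109%, the highest of the three numbers shown. Compound 2 `CN(Cc1ccc(C(=O)NCCS(=O)(=O)O)cc1)c1ccc(OCc2c(-c3c(Cl)cccc3Cl)noc2C2CC2)nc1C(F)(F)F` gives 105%, and compound 3 `CCN(Cc1ccc(C(=O)O)cc1)c1ccc(OCc2c(-c3c(Cl)cccc3Cl)noc2C2CC2)nc1C(F)(F)F` gives 94%. The first of these steps, a number 4 percentage points lower from compound 1 to compound 2 (within the scatter), changes the carboxylic acid end and leaves the response within the scatter; the second, a number 15 percentage points lower from compound 1 to compound 3 (beyond the scatter), touches the linker on the nitrogen and costs a modest amount. Compound 4 `O=C(O)c1ccc(OCc2ccc(OCc3c(-c4c(Cl)cccc4Cl)noc3C3CC3)nc2C(F)(F)F)cc1` differs from compound 1 at the linker: (4-carboxyphenoxy)methyl in place of (4-carboxybenzyl)(methyl)amino on an aromatic carbon. For the measured compounds named here, only the step to compound 3 bears on a linker change, and it was modest. Compound 4 is therefore expected to lose a modest amount, a number 14 percentage points lower from compound 1 to compound 4 (beyond the scatter), and its estimated value in this assay is 95%, in a range from 70% to 115%.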

Compound 4, largest response reached (reported as efficacy), in percent of the reference or control that the assay uses: 86%
Estimate against measurement, compound 4: 9 percentage points above; the range from low to high includes it.
By their numbers in this assay, from the lowest: compounds 4 and 3 (each within the scatter of the next); then compounds 2 and 1 (each within the scatter of the next).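

In this assay the linker swap at this aromatic carbon, ortho to a trifluoromethyl group, gives a number 23 percentage points lower from compound 1 to compound 4 (beyond the scatter) and thus lowers the maximal response, though a substantial response remains. The amino nitrogen of the (4-carboxybenzyl)(methyl)amino group is therefore not required for a substantial response, although the two linkers differ by more than that atom. Nothing measured here accounts for the loss. Going by these compounds, it remains open whether a sulfur atom in place of the linker oxygen, or a longer chain in the linker, would recover the response. Also open, on these data alone, is whether (2-sulfoethyl)amino on the carbonyl carbon would be tolerated with this linker as it is in compound 2.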